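Removing a Methyl from the Nitroaniline Side Chain

The source may hold more compounds than are shown below. What is called first, only, known or untested is meant among the compounds shown, and "the series" means these compounds.

Three compounds share one core and differ only in the outer aromatic ring and in the thiocarbonyl or carbonyl of the core. Compound 1 `CCOC(=O)C1=C(C)NC(=S)NC1c1cn(C(=O)CNc2ccccc2)c2ccccc12` has an unsubstituted outer ring, and in a functional assay on MCF7 cells (Homo sapiens) for cytotoxicity, read by MTT assay, with a stated time of 72 h (a higher number here means a weaker inhibitor, a lower number a stronger inhibitor), compound 1 gives 52 ug/mL. Compound 2 `CCOC(=O)C1=C(C)NC(=O)NC1c1cn(C(=O)CNc2ccc([N+](=O)[O-])cc2C)c2ccccc12` carries a nitro group and a methyl on that ring, and in this assay compound 2 gives 50 ug/mL, the lowest of the two numbers, with compound 1 as its nearest neighbour, within the scatter. Compound 3 `CCOC(=O)C1=C(C)NC(=S)NC1c1cn(C(=O)CNc2cccc([N+](=O)[O-])c2)c2ccccc12` gives in this assay only a limit, > 1000 ug/mL, which is the limit of > 1000 ug/mL in this assay, at which 1 of the 3 values shown sits.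

Compound 4 `CCOC(=O)C1=C(C)NC(=O)NC1c1cn(C(=O)CNc2ccc([N+](=O)[O-])cc2)c2ccccc12` differs from compound 2 by hydrogen in place of methyl on an aromatic carbon. For the measured compounds named here, the only measured step, an at least 19-fold higher number from compound 1 to compound 3 (1.28 log units; beyond the scatter), is a different change, nitro in place of hydrogen on an aromatic carbon, so it does not bear directly on removing a methyl. It does show, though, that compound 3, a nitro compound with no methyl, sits at the limit, whereas compound 2, a nitro compound with a methyl, gives a number. Loss of the methyl is therefore expected to raise the number modestly, with wide uncertainty. Compound 4 is expected to give 120 ug/mL (from 35 ug/mL to 1000 ug/mL), an estimated step of a 2.4-fold higher number from compound 2 to compound 4 (0.38 log units; beyond the scatter).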

Compound 4, half-maximal inhibitory concentration: > 1000 ug/mL
Compound 4: a limit, no number; the forecaster's own chance of this, stated with the estimate: 30%; middle value at least 8.3-fold (0.92 log units) away from the limit.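

For the compounds shown here, the methyl on the 2-methyl-4-nitrophenyl ring carries far more weight than the earlier compounds could show: in this assay, replacing it with hydrogen gives an at least 20-fold higher number from compound 2 to compound 4 (1.30 log units; beyond the scatter). Compound 4 gives > 1000 ug/mL, and this is a limit of the assay, not a number. The only earlier step concerned adding a nitro group to the outer ring, whereas this pair isolates a single carbon, on an aromatic carbon ortho to a large group and meta to a nitro group, and shows that its loss alone separates a readable value from a second compound at the limit: the limit of > 1000 ug/mL in this assay, at which 2 of the 4 values shown sit.

The compounds shown leave open whether this is specific to the methyl or whether another group in the same place, such as an ethyl group, a chlorine atom or a methoxy group, would also keep a readable value. Also open, as far as these compounds go, is whether the methyl would matter as much on a core with the thiocarbonyl of compound 1 and compound 3, as this single pair carries the carbonyl and supports no general rule.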